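The source may report more compounds than this note shows. Statements on the series, on what has been measured and on what is new or still open speak of the compounds shown alone.

Series notes, urea-linked set on the shared core of compound 1.

Among the measured compounds shown here, compound 1 `CC(=O)c1ccc(NC(=O)Nc2cc(C)nc3ccccc23)cc1` is the one member of the set with a number in an ADME assay on HepG2 cells (Homo sapiens) for cytotoxicity, with a stated time of 72 h; on this read-out higher numbers stand for an effect only at larger amounts of compound and lower numbers for an effect already at smaller amounts: compound 1 gives 19000 nM. Compound 2 `COc1ccc(NC(=O)Nc2cc(C)nc3ccccc23)cc1F` reaches only a limit of this assay, compound 2 giving > 25000 nM. Compound 3 `CSc1ccccc1NC(=O)Nc1cc(C)nc2ccccc12` likewise stops at a limit, compound 3 giving > 25000 nM. So compound 1 supplies the only measured point, the other two sitting at the limit of > 25000 nM in this assay, at which 2 of the 3 values shown sit.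

Compound 4 `Cc1cc(NC(=O)Nc2ccc(Cl)cc2)c2ccccc2n1` is not yet measured in this assay. Compound 4 differs from compound 1 in one place, (chloro in place of acetyl on an aromatic carbon). For the measured compounds named here, no step between measured compounds is available to size this change. The set as a whole reads weakly in this assay, with compound 1 at 19000 nM, so no step beyond the usual scatter is expected from compound 1 to compound 4. The expected step is a 1.1-fold lower number from compound 1 to compound 4 (0.05 log units; within the scatter). On that basis compound 4 is estimated at 17000 nM, with a range from 7000 nM to 25000 nM; a limit rather than a number is a real possibility.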

Compound 4, half-maximal effective concentration: > 25000 nM
Compound 4 gave a limit, no number (the forecaster's own chance of this, stated with the estimate: 40%); middle value at least 1.4-fold (0.16 log units) from the limit.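

Chloro in place of acetyl on this aromatic carbon, para to a large group, gives the first step that can be read at this position in this assay: an at least 1.3-fold higher number from compound 1 to compound 4 (0.11 log units; that floor lies within the scatter). Compound 4 stops at a limit of the assay, > 25000 nM, so this step has only a floor and its full size cannot be read. Compound 1 remains the only compound in the set with a number, and the acetyl group is the only group at this position tied to one: the limit of > 25000 nM in this assay, at which 3 of the 4 values shown sit.

From the compounds shown here alone, whether the change from acetyl to chloro moves the read-out beyond the usual scatter stays open. An amine or a carboxylic acid at this position, set against acetyl on the shared core, would show whether the number of compound 1 can shift in either direction.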